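Hydroxymethyl in place of formylaminomethyl on the aryl arm

The source may hold more compounds than are shown below. What is called first, only, known or untested is meant among the compounds shown, and "the series" means these compounds.

Compound 1 `Cn1nc2c(=O)n(CC3(O)CCN(Cc4ccc(-c5ccncc5)cc4Cl)CC3)cnc2c1-c1ccc(CN)cc1`: 257 nM
Compound 2 `Cn1nc2c(=O)n(CC3(O)CCN(Cc4ccc(-c5ccco5)cc4Cl)CC3)cnc2c1-c1ccc(CNC=O)cc1`: 20.9 nM
Compound 3 `Cn1cc(-c2ccc(CN3CCC(O)(Cn4cnc5c(-c6ccc(CN)cc6)n(C)nc5c4=O)CC3)c(Cl)c2)cn1`: 291 nM

In an assay on isolated protein for inhibition of ubiquitin carboxyl-terminal hydrolase 7 (Homo sapiens), with stated times of 30 min and 2 h (a higher number here means a weaker inhibitor, a lower number a stronger inhibitor), compound 2 gives the lowest number of the three; compound 1 and compound 3 both sit well above it, beyond the scatter, while a 1.1-fold higher number from compound 1 to compound 3 (0.05 log units; within the scatter) lies within the scatter. Compound 4 `Cn1nc2c(=O)n(CC3(O)CCN(Cc4ccc(-c5ccco5)cc4Cl)CC3)cnc2c1-c1ccc(CO)cc1` is not yet measured. It differs from compound 2 as follows: hydroxy in place of formylamino on a saturated chain carbon bound to an aromatic carbon. Among the compounds with values here, no measured step touches this position: the one step in hand swaps the distant heteroaryl, and compound 1 and compound 2 differ in two places at once, so their values cannot be split. On that thin basis compound 4 is expected to stay near compound 2, with a small weakening as the likelier direction, a 1.9-fold higher number from compound 2 to compound 4 (0.28 log units; within the scatter). The estimate for compound 4 is 40 nM, within 15 nM to 120 nM.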

Compound 4, half-maximal inhibitory concentration: 42.5 nM
Compound 4: middle estimate off by 1.1-fold (0.03 log units), on the low side; low and high end bracket the measured number.
By their numbers in this assay, from the lowest: compound 2; then compound 4; then compounds 1 and 3 (each within the scatter of the next).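

In this assay, within the data shown here, the first measured step at this position is modest: a 2.0-fold higher number from compound 2 to compound 4 (0.31 log units; beyond the scatter). Cutting formylamino, with its three heavy atoms, down to the single heavy atom of hydroxy on this saturated chain carbon therefore costs little, and the formyl carbonyl is not required for a number in this range. No measurement on hand explains the step.

From the compounds shown here alone, whether a methyl ether or a carboxylic acid in place of the hydroxy would hold the number remains open. So does the effect of a longer chain between the aromatic carbon and the hydroxy.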